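This account rests on a few compounds, and the source may have more. Where it says the series, first, only, none or still open, it means among the compounds named here.

Measured compounds:
compound 1 `CCOC(=O)c1c(C)[nH]c(=O)c(C#N)c1-c1ccc(C)cc1` gives 8000 nM
compound 2 `CCOC(=O)c1c(C)[nH]c(=O)c(C#N)c1-c1ccc(OC)cc1` gives 36100 nM

In a functional assay on MCF7 cells (Homo sapiens) for inhibition, read by MTT assay, with a stated time of 24 h (on this read-out higher numbers stand for weaker inhibition and lower numbers for stronger inhibition), compound 2 stands with the highest of the two numbers; its nearest neighbour is compound 1, and the step between them is a 4.5-fold higher number from compound 1 to compound 2 (0.65 log units; beyond the scatter). Compound 3 `CCOC(=O)c1c(C)[nH]c(=O)c(C#N)c1-c1ccc(C#N)cc1` differs from compound 2 by cyano in place of methoxy on an aromatic carbon. Going by the values given here, the single measured step concerns methyl giving way to methoxy, not methoxy giving way to cyano, so it offers no direct guide to this change. Lacking a comparable step, no movement beyond the scatter is expected, and compound 3 is estimated at 22000 nM, with a range from 6000 nM to 70000 nM, an expected step of a 1.6-fold lower number from compound 2 to compound 3 (0.22 log units; within the scatter).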

Compound 3, half-maximal inhibitory concentration: 9320 nM
Estimate against measurement, compound 3: 2.4-fold (0.37 log units) above; the range from low to high includes it.
By their numbers in this assay, from the lowest: compounds 1 and 3 (each within the scatter of the next); then compound 2.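

Putting cyano in place of methoxy on this aromatic carbon gives a 3.9-fold lower number from compound 2 to compound 3 (0.59 log units; beyond the scatter) in this assay, so the number at this position can also fall back after the rise seen with methoxy. Cyano in place of methyl gives a 1.2-fold higher number from compound 1 to compound 3 (0.07 log units; within the scatter), which leaves methoxy as the only one of these three groups that stands apart. Nothing measured here explains why methoxy differs.

As far as these compounds go, whether an amine, a carboxylic acid or a longer chain at this position would group with methoxy or with the other two remains open. So does whether the same pattern would hold in any other assay.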